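Chloro in Place of Fluoro on the Shared Core

The compounds below may be only part of what the source reports. "The series", "measured", "known", "first", "only" and "open" are said of these compounds alone.

In an ADME assay on CCRF-CEM cells (Homo sapiens) for antiproliferative activity, with a stated time of 48 h (a lower number here means a stronger inhibitor, a higher number a weaker inhibitor), compound 3 (`Nc1ccc(/C=C/C(=O)c2ccc(F)cc2)cc1`) reads 39000 nM and so belongs to the high end of the three measured numbers. It shares that end with compound 2 (`Nc1ccc(/C=C/C(=O)c2ccccc2)cc1`) at 34000 nM and lies within the scatter of it. Compound 1 (`C=C(Br)C(=O)Nc1ccc(/C=C/C(=O)c2ccc(Cl)cc2)cc1`) stands far lower at 950 nM in the same test.

Compound 4 (`Nc1ccc(/C=C/C(=O)c2ccc(Cl)cc2)cc1`) differs from compound 3 by a single swap, chloro in place of fluoro on an aromatic carbon, para to a large group. Among the measured compounds shown here, one measured step bears on this swap. Fluoro in place of hydrogen on an aromatic carbon gave a 1.1-fold higher number from compound 2 to compound 3 (0.06 log units; within the scatter) and did not move the number beyond the scatter. Compound 1 also carries chloro on an aromatic carbon, but it differs from compound 4 elsewhere as well, so it does not isolate the swap. For the measured compounds named here, no measured step involves chloro alone.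

On this single small step, no change beyond the scatter is expected in this assay in either direction. The expected step is a 1.2-fold lower number from compound 3 to compound 4 (0.09 log units; within the scatter) and lies within the scatter. Compound 4 is expected at 32000 nM within an estimated range of 15000 nM to 60000 nM on this measure.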

Compound 4, half-maximal inhibitory concentration: 21000 nM
The estimate for compound 4 lay 1.5-fold (0.18 log units) above the measured number; low and high end bracket the measured number.
By their numbers in this assay, from the lowest: compound 1; then compounds 4, 2 and 3 (each within the scatter of the next).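

In this assay, chloro in place of fluoro on the aromatic carbon gives a 1.9-fold lower number from compound 3 to compound 4 (0.27 log units; within the scatter) and chloro in place of hydrogen gives a 1.6-fold lower number from compound 2 to compound 4 (0.21 log units; within the scatter), so hydrogen, fluoro and chloro at this place on the shared core all read alike within the scatter. Among the compounds shown here, the one step beyond the scatter lies elsewhere: hydrogen in place of (1-bromoethenyl)carbonyl on the nitrogen gives a 22-fold higher number from compound 1 to compound 4 (1.34 log units; beyond the scatter), which shows that with chloro held constant, the gap between compound 1 and compound 4 goes with the group on that nitrogen and not with the halogen. Nothing in hand explains either the flat halogen series or this large step.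

The compounds shown leave open whether a methoxy or a nitrile on the same aromatic carbon would also stay within the scatter. They also leave open whether a plain acetyl on the nitrogen would match the (1-bromoethenyl)carbonyl group, and whether that group would give a step of similar size on the cores of compound 2 and compound 3.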